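The source may report more compounds than this note shows. Statements on the series, on what has been measured and on what is new or still open speak of the compounds shown alone.

Measured so far in a functional assay on the whole organism for inhibition, with Rattus norvegicus as the target, read by cytopathic effect and paw edema, at a dose of 100 mg/kg by the oral route; on this read-out higher numbers stand for more inhibition at the one dose given (going by the name of the read-out) and lower numbers for less inhibition:

compound 1, `CCCCNC(=O)c1c(O)c2cccnc2n(-c2ccccc2)c1=O`: 20.4%
compound 2, `O=C(Nc1ccccc1)c1c(O)c2cccnc2n(-c2ccccc2)c1=O`: -15%
compound 3, `Cc1ccc(NC(=O)c2c(O)c3cccnc3n(-c3ccccc3)c2=O)cc1`: 2.2%

Compound 3 stands second highest of the three numbers. It sits between the others: a number 18.2 percentage points lower from compound 1 to compound 3 (beyond the scatter), and a number 17.2 percentage points higher from compound 2 to compound 3 (beyond the scatter). The unmeasured compound 4, `COc1ccc(NC(=O)c2c(O)c3cccnc3n(-c3ccccc3)c2=O)cc1`, differs from compound 3 in one place: methoxy in place of methyl on an aromatic carbon. For the measured compounds named here, the only measured step that touches the same aromatic carbon is the modest rise seen for a number 17.2 percentage points higher from compound 2 to compound 3 (beyond the scatter), where a methyl replaced hydrogen; no measured step trades methyl for methoxy, so that step is at best a loose guide. A step of no more than the usual scatter is therefore expected: a number 2.8 percentage points higher from compound 3 to compound 4 (within the scatter). Compound 4 is estimated at 5%, with a range from -15% to 25%.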

Compound 4, a percentage reported as inhibition, in the whole organism at one dose (the size of the read-out at that dose, not a potency): -1.9%
Estimate against measurement, compound 4: 6.9 percentage points above; the range from low to high includes it.
By their numbers in this assay, from the lowest: compound 2; then compounds 4 and 3 (each within the scatter of the next); then compound 1.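

On the aromatic carbon para to a large group, methoxy in place of methyl gives a number 4.1 percentage points lower from compound 3 to compound 4 (within the scatter), so this swap does not separate the two groups on this read-out. Methoxy in place of hydrogen there gives a number 13.1 percentage points higher from compound 2 to compound 4 (beyond the scatter), the same direction as methyl, while 4-methoxyphenyl in place of butyl on the amide-type nitrogen gives a number 22.3 percentage points lower from compound 1 to compound 4 (beyond the scatter). No measurement available here explains these steps. Going by these compounds, whether an amine or a carboxylic acid on that carbon, or a longer chain in place of butyl, would move the number remains open.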